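The compounds below may be only part of what the source reports. "The series", "measured", "known", "first", "only" and "open" are said of these compounds alone.

Of the compounds shown here, three have been tested in a functional assay on L6 cells (Rattus norvegicus) for cytotoxicity; on this read-out lower numbers stand for stronger inhibition and higher numbers for weaker inhibition. Compound 1 `N=C(N)c1ccc(-c2ccc(-c3ccc(C(=N)N)o3)cc2)cc1` gives 56100 nM, and compound 2 `CONC(=N)c1ccc(-c2ccc(-c3ccc(C(=N)NOC)cc3)c(F)c2)cc1` gives 8500 nM, so both of these have true numbers, with compound 2 the lower of the pair. Compound 3 `N=C(NO)c1ccc(-c2ccc(-c3ccc(/C(N)=N\O)cc3)cc2)cc1` has no number, only a limit of > 211000 nM. The record for compound 3 is the limit of > 211000 nM in this assay, at which 1 of the 3 values shown sits. Any comparison that begins at compound 3 therefore begins at a limit rather than at a measured value.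

Compound 4 `N=C(NO)c1ccc(-c2ccc(-c3ccc(/C(N)=N\O)cc3)cc2C(F)(F)F)cc1` differs from compound 3 in one place, with trifluoromethyl in place of hydrogen on an aromatic carbon. For the measured compounds named here, no two measured compounds differ in just one place, so the data offer no direct measure of what such a swap does in this assay. A modest move towards lower numbers is expected, though the reading could again be only a limit. That expectation leans on compound 1 at 56100 nM and on compound 2 at 8500 nM, which show that related structures can give measurable values in this assay. The estimated step is an at least 2.1-fold lower number from compound 3 to compound 4 (0.32 log units; beyond the scatter). For compound 4 the estimated value is 100000 nM, with an expected range from 25000 nM to 220000 nM.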

Compound 4, half-maximal inhibitory concentration: 13300000 nM
Compound 4: middle estimate off by 130-fold (2.12 log units), on the low side, and the stated range ends below it.
By their numbers in this assay, from the lowest: compound 2; then compound 1; then compound 4.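

No size can be read for the change from compound 3 to compound 4, because compound 3 has a limit and not a number: the limit of > 211000 nM in this assay, at which 1 of the 4 values shown sits.

The compounds shown leave open how far trifluoromethyl in place of hydrogen on an aromatic carbon moves the number in this assay when both partners of a pair have true values.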